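Cyclopropyl for methyl on the amide of compound 2

A few compounds are considered here, and "the series" means these few. Any claim that something is new, unique, unknown or untested is made for them only; others in the source may bear on it.

Measured so far:
Compound 1, `O=C(Nc1nc2ccc(-c3cn([C@@H]4CN[C@H](C(=O)Nc5ccc(Cl)c(C(F)(F)F)c5)C4)nn3)nc2s1)C1CC1`: 10.4%
Compound 2, `CC(=O)Nc1nc2ccc(-c3cn([C@@H]4CN[C@H](C(=O)Nc5ccc(F)c(F)c5)C4)nn3)nc2s1`: 38.4%

In a functional assay on K562/Adr cells (Homo sapiens) for inhibition, read by MTT assay, with a stated time of 48 h, tested at 30 uM (on this read-out higher numbers stand for more inhibition at the one concentration tested (going by the name of the read-out) and lower numbers for less inhibition), compound 2 gives 38.4%, the higher of the two numbers in hand. In this assay compound 1 gives 10.4%, a number well beyond the scatter below that of compound 2. Compound 1 and compound 2 differ in more than one place, so the two values alone do not show which part of the difference carries the gap.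

Compound 3, `O=C(Nc1nc2ccc(-c3cn([C@@H]4CN[C@H](C(=O)Nc5ccc(F)c(F)c5)C4)nn3)nc2s1)C1CC1`, is the next compound to be tested in this assay. Relative to compound 2 it carries one change: cyclopropyl in place of methyl on a carbonyl carbon

Within the data shown here, the one comparison that contains a cyclopropylcarbonyl group, compound 1, also carries a different aryl part, so no clean read on the acetyl to cyclopropylcarbonyl change exists among the measured compounds. The step of a number 12.4 percentage points lower from compound 2 to compound 3 (beyond the scatter) is therefore expected to be a moderate fall, though a result within the scatter would not be surprising. Compound 3 is expected to give 26% in this assay, with a range from 8% to 48%.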

Compound 3, a percentage reported as inhibition, at one concentration (the size of the read-out at that concentration, not a potency): 29.5%
Estimate against measurement, compound 3: 3.5 percentage points below; low and high end bracket the measured number.
By their numbers in this assay, from the lowest: compound 1; then compounds 3 and 2 (each within the scatter of the next).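

In this assay the change from acetyl to cyclopropylcarbonyl gives a number 8.9 percentage points lower from compound 2 to compound 3 (within the scatter) and so, on this read-out, the cyclopropyl group at this carbonyl carbon can be told apart from methyl by no more than the usual scatter. With cyclopropylcarbonyl held fixed, 3,4-difluorophenyl in place of 4-chloro-3-(trifluoromethyl)phenyl on the amide-type nitrogen gives a number 19.1 percentage points higher from compound 1 to compound 3 (beyond the scatter) and thereby supplies the first clean read on the aryl part, the only one of the two single changes now readable that lies beyond the scatter. No measured property of these compounds is available that would account for either step.

On these data alone, the acyl change has been read only with the 3,4-difluorophenyl group in place, so whether it stays within the scatter with 4-chloro-3-(trifluoromethyl)phenyl remains open. Only acetyl and cyclopropylcarbonyl appear at this carbonyl carbon, which leaves open how a longer chain such as butanoyl, or an acyl group carrying an amine or a carboxylic acid, would read in this assay at the one concentration used.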